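The source may report more compounds than this note shows. Statements on the series, on what has been measured and on what is new or still open speak of the compounds shown alone.

Three compounds of the series have a reading in a functional assay on A375P cells (Homo sapiens) for antiproliferative activity; a higher number here means a weaker inhibitor, a lower number a stronger inhibitor. Compound 1 `Cc1ccc(NC(=O)Nc2ccc(Cl)c(Cl)c2)cc1NC(=O)c1ccccc1` gives 5800 nM in this assay. Compound 2 `Cc1ccc(NC(=O)Nc2cc(Cl)cc(Cl)c2)cc1NC(=O)c1ccccc1` gives 259 nM in this assay, and the step of a 22-fold lower number from compound 1 to compound 2 (1.35 log units; beyond the scatter) is the largest movement among the measured pairs. Compound 3 `Cc1ccc(NC(=O)Nc2ccc(C)c(NC(=O)c3ccccc3)c2)cc1C` gives > 30000 nM in this assay, and this is a limit of the assay, not a number. Among the measured compounds shown here, compound 3 therefore sits at the limit of > 30000 nM in this assay, at which 1 of the 3 values shown sits, and is the one compound of the three with no numerical value. The steps that reach it are an at least 5.1-fold higher number from compound 1 to compound 3 (0.71 log units; beyond the scatter) and an at least 110-fold higher number from compound 2 to compound 3 (2.06 log units; beyond the scatter), both beyond the scatter, both running to a higher number when the 3,4-dimethylphenyl group enters.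

Compound 4 `CC(=O)c1cccc(NC(=O)Nc2ccc(C)c(NC(=O)c3ccccc3)c2)c1` differs from compound 3 in one place: 3-acetylphenyl in place of 3,4-dimethylphenyl on an amide-type nitrogen. For the measured compounds named here, no measured pair carries the 3-acetylphenyl group, so the only steps that bear on this change are the two that install the 3,4-dimethylphenyl group, and both were large. Each change away from that group so far gave a lower number. Compound 4 is thus expected to move toward a lower number, with the size of the move uncertain. The expected step is an at least 3.0-fold lower number from compound 3 to compound 4 (0.47 log units; beyond the scatter). Compound 4 is estimated at 10000 nM in this assay, within a range of 2000 nM to 30000 nM.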

Compound 4, half-maximal inhibitory concentration: 9800 nM
The estimate for compound 4 lay 1.0-fold (0.01 log units) above the measured number, and the stated range covers the measured number.
By their numbers in this assay, from the lowest: compound 2; then compounds 1 and 4 (each within the scatter of the next). At a limit, above all of these: compound 3.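

The change to the 3-acetylphenyl group gives an at least 3.0-fold lower number from compound 3 to compound 4 (0.48 log units; beyond the scatter), which is a bound and not a size, since compound 3 stands at a limit of the assay: the limit of > 30000 nM in this assay, at which 1 of the 4 values shown sits. Chlorine is therefore not required for a numerical reading in this assay at this place on the amide-type nitrogen, and the 3-acetylphenyl group cannot be told apart from the 3,4-dichlorophenyl group, with a 1.7-fold higher number from compound 1 to compound 4 (0.23 log units; within the scatter). The 3,5-dichlorophenyl group stays clearly apart, with a 38-fold higher number from compound 2 to compound 4 (1.58 log units; beyond the scatter), so among the four compounds the low number belongs to that one group and not to chlorine as such, as compound 1 also carries two chlorines without reaching it.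

On these data alone, what a 3,5-dimethylphenyl group would read remains open, and with it whether the reading of compound 2 follows the arrangement of the two substituents or the chlorine atoms themselves. Also open, as far as these compounds go, is whether the carbonyl of the 3-acetylphenyl group matters to the reading of compound 4, a question that a 3-ethylphenyl or a 3-carboxyphenyl group at the same place would address.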